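Compound 2 to compound 4: replacing dimethylamino

The source may hold more compounds than are shown below. What is called first, only, known or untested is meant among the compounds shown, and "the series" means these compounds.

In a functional assay (aorta) with Rattus norvegicus as the target (on this read-out lower numbers stand for an effect already at smaller amounts and higher numbers for an effect only at larger amounts of compound), compound 2 (`COc1ccc(-c2nc(CN(C)C)sc2-c2ccc(OC)cc2)cc1`) gives 8.4 uM. Compound 3 (`COc1ccc(-c2nc(CNC(=O)CSc3ccccc3)sc2-c2ccc(OC)cc2)cc1`) gives 4.2 uM, which lies within the scatter of compound 2. Compound 1 (`COc1ccc(-c2nc(/N=C(\N)[N+]3(C)CCCCC3)sc2-c2ccc(OC)cc2)cc1`) gives 21 uM, which is clear of compound 2 by more than the scatter.

Compound 4 (`CNC(=O)NCc1nc(-c2ccc(OC)cc2)c(-c2ccc(OC)cc2)s1`) keeps the shared core and is still unmeasured. Its change from compound 2 is (methylcarbamoyl)amino in place of dimethylamino on a saturated chain carbon bound to an aromatic carbon.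

Within the data shown here, the closest precedent is a 2.0-fold lower number from compound 2 to compound 3 (0.30 log units; within the scatter), where another group replaces dimethylamino at the same carbon. The other measured step, a 2.5-fold lower number from compound 1 to compound 2 (0.40 log units; beyond the scatter), is modest and concerns a group on an aromatic carbon, so it bears less directly. On this basis, no change beyond the scatter is expected in this assay, with a slightly lower number the likelier direction. The expected step is a 1.4-fold lower number from compound 2 to compound 4 (0.15 log units; within the scatter). For compound 4 the estimated value is 6 uM, with an expected range of 2.5 uM to 15 uM.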

Compound 4, concentration for half-maximal effect: 15 uM
For compound 4 the middle estimate is 2.5-fold (0.40 log units) below the measured one; low and high end bracket the measured number.
By their numbers in this assay, from the lowest: compounds 3, 2, 4 and 1 (each within the scatter of the next, the first and the last beyond it).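

In this assay the swap to (methylcarbamoyl)amino on the saturated chain carbon bound to an aromatic carbon gives a 1.8-fold higher number from compound 2 to compound 4 (0.25 log units; within the scatter), so this urea-type group and dimethylamino are not separated at this position. The sharper information lies on the carbonyl carbon, where methylamino in place of (phenylsulfanyl)methyl gives a 3.6-fold higher number from compound 3 to compound 4 (0.55 log units; beyond the scatter), which shows that the read-out responds to what is carried on that carbonyl even when the rest of the structure is held constant. Compound 4 is also not separated from the bulkier group on the aromatic carbon in compound 1, with a 1.4-fold lower number from compound 1 to compound 4 (0.15 log units; within the scatter) as the step.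

As far as these compounds go, whether the phenyl ring or the sulfur of the (phenylsulfanyl)methyl group carries the step from compound 3 stays open, as does the reading for a carboxylic acid or a longer alkyl chain on the same carbon. No supporting data bear on why these groups read as they do.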